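The source may report more compounds than this note shows. Statements on the series, on what has been measured and on what is new or still open speak of the compounds shown alone.

Three compounds share one core. In a functional assay on CHO cells with sphingosine 1-phosphate receptor 4 (Homo sapiens) as the target, read by GTPgammaS binding (a higher number here means that more compound is needed for the effect, a lower number that less compound is needed), compound 1 `Cc1cc(CCC(=O)O)ccc1-c1noc(-c2ccc(OC(C)C)c(F)c2)n1` gives > 10000 nM, which is a limit of the assay rather than a number. Compound 2 `Cc1cc(-c2nc(-c3ccc(CCC(=O)O)cc3C)no2)ccc1OC(C)C` likewise gives > 10000 nM, again a limit. Compound 3 `Cc1cc(CCC(=O)O)ccc1-c1noc(-c2ccc(OC(C)C)c(C#N)c2)n1` gives > 10000 nM, also a limit. All three sit at the limit of > 10000 nM in this assay, at which 3 of the 3 values shown sit, so the steps a step that the two limits leave unreadable from compound 1 to compound 2, a step that the two limits leave unreadable from compound 1 to compound 3 and a step that the two limits leave unreadable from compound 2 to compound 3 cannot be sized. Among the compounds with values here, compound 4 `Cc1cc(CCC(=O)O)ccc1-c1noc(-c2ccc(OC(C(F)(F)F)C(F)(F)F)c(C#N)c2)n1` differs from compound 3 by 2,2,2-trifluoro-1-(trifluoromethyl)ethyl in place of isopropyl on an oxygen on an aromatic ring, a change at the oxygen on an aromatic ring that none of the measured steps touches. Within the data shown here, no measured step bears on it, and the step from compound 3 to compound 4 is expected at a number no higher from compound 3 to compound 4 (the limit leaves the size open). Compound 4 is estimated at 10000 nM, within a range from 1500 nM to 50000 nM.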

Compound 4, half-maximal effective concentration: > 10000 nM
Compound 4: no number, only a limit; the forecaster's own chance of this, stated with the estimate: 70%; the middle value lies on the limit itself.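

In this assay compound 4 gives > 10000 nM, again a limit and not a number, so the step between compound 3 and compound 4 cannot be read. The compounds shown leave open where any of the four truly lies, and so how their groups compare: the limit of > 10000 nM in this assay, at which 4 of the 4 values shown sit.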